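A few compounds are considered here, and "the series" means these few. Any claim that something is new, unique, unknown or untested is made for them only; others in the source may bear on it.

Measured compounds:
- compound 1, `Cc1ccc(C[C@H]2C(=O)OC[C@@H]2Cc2ccccc2)cc1`: in a functional assay on HeLa cells (Homo sapiens) for cytotoxicity, read by WST assay, with a stated time of 48 h (a higher number here means that more compound is needed for the effect, a lower number that less compound is needed), compound 1 gives "not determined" (no result reported)
- compound 2, `O=C1OC[C@H](Cc2ccccc2)[C@H]1Cc1ccc(Cl)c(Cl)c1`: in this assay compound 2 gives 26000 nM
- compound 3, `O=C1OC[C@H](Cc2ccccc2O)[C@H]1Cc1ccc(Cl)c(Cl)c1`: in this assay compound 3 gives "not determined" (no result reported)

Among the measured compounds shown here, compound 3 stands without a number in this assay: its entry reads "not determined" (no result reported), and the same holds for compound 1, whose entry reads "not determined" (no result reported), so the only number so far is that of compound 2. The shared core of compound 2 and compound 3 carries the same dichlorinated benzyl group; they differ only in the second benzyl group, which in compound 3 bears a hydroxy. Compound 2 gives 26000 nM in this assay, a weak effect.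

Compound 4 is `COc1ccccc1C[C@H]1COC(=O)[C@@H]1Cc1ccc(Cl)c(Cl)c1`. The change from compound 3 to compound 4 is methyl in place of hydrogen on an oxygen on an aromatic ring. For the measured compounds named here, no step between two measured compounds is available, so the size of this step in this assay cannot be read from the series; it is expected to be small, within the usual scatter, in either direction, and the number for compound 4 is expected to sit near that of compound 2. Compound 4 is estimated at 25000 nM in this assay, in a range from 8000 nM to 80000 nM, with a real chance that only a limit is reported.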

Compound 4, half-maximal effective concentration: 24000 nM
Compound 4: middle estimate off by 1.0-fold (0.02 log units), on the high side; low and high end bracket the measured number.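

With compound 4 the series gains its first step between two numbers: in this assay the record reads a 1.1-fold lower number from compound 2 to compound 4 (0.03 log units; within the scatter). On this aromatic carbon of the second benzyl group, methoxy in place of hydrogen therefore gives no difference that can be separated from the scatter, and the 2-methoxyphenyl compound stays as weak as the compound with the unsubstituted benzyl group. The earlier compounds shown here could not show this, as compound 2 alone carried a number and there was nothing to set it against.

Steps that involve compound 1 or compound 3, including hydroxy to methoxy, cannot be read, as neither compound has a number. Going by these compounds, it remains open whether a group such as an amine, a carboxylic acid or a longer alkoxy chain on this aromatic carbon would move the number beyond the scatter, and whether the same methoxy would behave alike on another carbon of that ring.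

No measurement in hand bears on this result or offers an explanation for it.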